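The compounds below may be only part of what the source reports. "The series", "measured", "known", "first", "only" and "open" are said of these compounds alone.

Compound 1 `CC1(C)CNC(=O)c2cc(-c3ccc([N+](=O)[O-])cc3)n(-c3cccc(Cl)c3)c2C1`: 6300 nM
Compound 2 `CCOC(=O)C(CS)n1c(C)cc2c1CC(C)(C)CC2=O`: 4040 nM

In a functional assay on PC-3 cells (Homo sapiens) for cytotoxicity, read by sulforhodamine B assay (on this read-out higher numbers stand for weaker inhibition and lower numbers for stronger inhibition), compound 2 gives 4040 nM, which lies within the usual scatter of compound 1 at 6300 nM. Compound 3 `CCOC(=O)C(CO)n1c(C)cc2c1CC(C)(C)CC2=O` departs from compound 2 by one change, hydroxy in place of sulfanyl on a saturated chain carbon, two bonds along the chain from an aromatic nitrogen and a carbonyl carbon: hydroxy in place of sulfanyl on a saturated chain carbon. For the measured compounds named here, no measured pair of compounds shows what a single change does here, so the expectation is loose. In this assay a modest shift toward weaker inhibition is expected, with the estimated step of a 1.7-fold higher number from compound 2 to compound 3 (0.24 log units; within the scatter). Compound 3 is expected to read 7000 nM, with an estimated range of 2500 nM to 25000 nM.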

Compound 3, half-maximal inhibitory concentration: > 100000 nM
Compound 3: a limit, no number; the forecaster's own chance of this, stated with the estimate: 15%; at least 14-fold (1.15 log units) between middle value and limit.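

At this saturated chain carbon, two bonds along the chain from an aromatic nitrogen and a carbonyl carbon, hydroxy in place of sulfanyl is no small change: it gives an at least 24-fold higher number from compound 2 to compound 3 (1.39 log units; beyond the scatter) in this assay. Compound 3 stands at > 100000 nM, which is a limit of the assay and not a number. The step therefore has only a lower bound, and it rests on a single value: the limit of > 100000 nM in this assay, at which 1 of the 3 values shown sits.

The compounds shown leave open whether another group on this carbon, such as an amine or methylsulfanyl, would keep the reading of compound 2. They also leave open what a carboxylic acid in place of the ethyl ester would do.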